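The compounds below may be only part of what the source reports. "The series", "measured", "known", "first", "only" and "open" are said of these compounds alone.

Working notes on the step from compound 3 to compound 4. In a physicochemical assay for solubility, measured as kinetic solubility (a lower number here means a less soluble compound, a higher number a more soluble compound), compound 1 (`O=C1CCCN1Cc1n[nH]c(-c2ncc3cccnc3c2O)n1`) reads > 250000 nM as a limit of the assay and not a number. Compound 2 (`CNc1ccnc2c(O)c(-c3nc(C)n[nH]3)ncc12`) reads > 250000 nM as a limit too. For the measured compounds named here, compound 3 (`Cc1n[nH]c(-c2ncc3c(N(C)C)ccnc3c2O)n1`) reads > 250000 nM as a limit as well, so its standing is known only as a limit and no compound has a number: the limit of > 250000 nM in this assay, at which 3 of the 3 values shown sit, applies throughout.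

Compound 4 (`COc1ccccc1-c1ccnc2c(O)c(-c3nc(C)n[nH]3)ncc12`) has 2-methoxyphenyl in place of dimethylamino on an aromatic carbon, opposite the ring nitrogen: 2-methoxyphenyl in place of dimethylamino on an aromatic carbon is the full count of that change.

Going by the values given here, the only measured step is a step that the two limits leave unreadable from compound 2 to compound 3 and it offers no size to carry forward. Among the compounds with values here, no measured step involves a change of this kind, so the expectation rests on the count of the change alone, with its added aromatic ring and larger group. A readable result in this assay can only fall on the low side of compound 3 at > 250000 nM as a limit. The estimated step is an at least 2.5-fold lower number from compound 3 to compound 4 (0.39 log units; beyond the scatter) and it is expected to point to a less soluble compound, with low confidence in its size. For compound 4 the estimate is 100000 nM with an expected range from 25000 nM to 250000 nM and a reading at the limit remains possible.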

Compound 4, solubility: > 250000 nM
Compound 4: no number, only a limit (the forecaster's own chance of this, stated with the estimate: 30%); middle value at least 2.5-fold (0.39 log units) from the limit.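

In this assay compound 4 gives > 250000 nM, a limit of the assay and not a number. The steps to compound 4 from compound 2 and from compound 3 therefore cannot be read, and the series offers no comparison: the limit of > 250000 nM in this assay, at which 4 of the 4 values shown sit.

The compounds shown leave open how large any change on the aromatic carbon opposite the ring nitrogen is in this assay.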